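The source may hold more compounds than are shown below. What is called first, only, known or untested is meant among the compounds shown, and "the series" means these compounds.

Three compounds share one core and differ only in the aromatic group attached at one place on it. Compound 1 `Cn1nc2c(=O)n(CC3(O)CCN(Cc4ccc(-c5ccncc5)cc4Cl)CC3)cnc2c1-c1ccc(CN)cc1` gives 257 nM in an assay on isolated protein for inhibition of ubiquitin carboxyl-terminal hydrolase 7 (Homo sapiens), with stated times of 30 min and 2 h; on this read-out higher numbers stand for weaker inhibition and lower numbers for stronger inhibition. Compound 2 `Cn1nc2c(=O)n(CC3(O)CCN(Cc4ccc(-c5cncs5)cc4Cl)CC3)cnc2c1-c1ccc(CN)cc1` gives 117 nM, and compound 3 `Cn1nc2c(=O)n(CC3(O)CCN(Cc4ccc(-c5ccco5)cc4Cl)CC3)cnc2c1-c1ccc(CN)cc1` gives 18.1 nM, the lowest of the three numbers. The measured steps were a 2.2-fold lower number from compound 1 to compound 2 (0.34 log units; beyond the scatter), a 14-fold lower number from compound 1 to compound 3 (1.15 log units; beyond the scatter) and a 6.5-fold lower number from compound 2 to compound 3 (0.81 log units; beyond the scatter). Compound 4 `Cn1nc2c(=O)n(CC3(O)CCN(Cc4ccc(-n5ccnc5)cc4Cl)CC3)cnc2c1-c1ccc(CN)cc1` differs from compound 3 by 1H-imidazol-1-yl in place of furan-2-yl on an aromatic carbon. Among the measured compounds shown here, every swap at this place so far moved the number beyond the scatter, so a step is expected here too. Because compound 3 sits at 18.1 nM while the other rings gave higher numbers, compound 4 is expected to land higher, by an 8.3-fold higher number from compound 3 to compound 4 (0.92 log units; beyond the scatter). The estimate for compound 4 is 150 nM, with a range from 40 nM to 550 nM.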

Compound 4, half-maximal inhibitory concentration: 228 nM
Compound 4: the middle estimate sits 1.5-fold (0.18 log units) below what was measured; the measured number falls inside the stated range.
By their numbers in this assay, from the lowest: compound 3; then compounds 2, 4 and 1 (each within the scatter of the next, the first and the last beyond it).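

Replacing furan-2-yl with 1H-imidazol-1-yl gives a 13-fold higher number from compound 3 to compound 4 (1.10 log units; beyond the scatter), so a five-membered aromatic ring of the same heavy-atom count does not by itself preserve the low number of compound 3. Among the compounds shown here, the comparisons with the other rings give a 1.9-fold higher number from compound 2 to compound 4 (0.29 log units; within the scatter) and a 1.1-fold lower number from compound 1 to compound 4 (0.05 log units; within the scatter), the first swaps at this place to stay within the scatter. No available evidence explains the separation of furan-2-yl from these rings.

As far as these compounds go, whether a thiophen-2-yl ring, with sulfur in place of the furan oxygen, would keep the low number remains open. So does the outcome for a plain phenyl ring.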